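Swapping a Hydroxyphenyl for a Bromophenyl on the Hydrazone

A few compounds are considered here, and "the series" means these few. Any claim that something is new, unique, unknown or untested is made for them only; others in the source may bear on it.

Compound 2 `O=C(COc1cccc2ccccc12)N/N=C/c1cccc(O)c1` stands second highest of three in a physicochemical assay for lipophilicity, measured as octanol-water partition (a lower number here means a more polar compound, a higher number a more lipophilic compound), where compound 2 gives 3.73. Nearest to it is compound 3 `COc1ccc(/C=N/NC(=O)COc2cccc3ccccc23)cc1O`, which gives 3.48; furthest from it is compound 1 `O=C(COc1cccc2ccccc12)N/N=C/c1ccc(Cl)cc1`, which gives 4.54. The step from compound 2 to compound 3, methoxy in place of hydrogen on an aromatic carbon, was a number 0.25 log units lower from compound 2 to compound 3 (within the scatter). The step of a number 0.81 log units lower from compound 1 to compound 2 (beyond the scatter), 3-hydroxyphenyl in place of 4-chlorophenyl on a carbon with a double bond to nitrogen, was the only one beyond the scatter.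

Compound 4 `O=C(COc1cccc2ccccc12)N/N=C/c1ccc(Br)cc1` differs from compound 2 by 4-bromophenyl in place of 3-hydroxyphenyl on a carbon with a double bond to nitrogen. This is nearly the reverse of the step from compound 1 to compound 2, so the number in this assay is expected to rise by about as much, with compound 1 at 4.54 as the closest measured reference. Compound 4 is therefore expected to give 4.7, between 4.3 and 5.1. The estimated step is a number 0.97 log units higher from compound 2 to compound 4 (beyond the scatter).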

Compound 4, partition coefficient: 4.81
Beside the measured number, compound 4's estimate is 0.11 log units below it; the range from low to high includes it.
By their numbers in this assay, from the lowest: compounds 3 and 2 (each within the scatter of the next); then compounds 1 and 4 (each within the scatter of the next).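

At the carbon with a double bond to nitrogen, replacing 3-hydroxyphenyl with 4-bromophenyl gave a large step, a number 1.08 log units higher from compound 2 to compound 4 (beyond the scatter), in this assay. Bromo in place of chloro on the aromatic carbon gave a number 0.27 log units higher from compound 1 to compound 4 (within the scatter), so this assay does not separate these two groups, and compound 1 and compound 4 together form the upper pair of the four compounds. No measurement shown here accounts for the size of either step.

The 3-hydroxyphenyl and 4-bromophenyl groups differ in both the substituent and its place on the ring, and the compounds shown do not separate those two changes. From the compounds shown here alone, how an amine or a carboxylic acid on the phenyl ring would stand in this assay also remains open.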